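Cytotoxicity limits in the aryl-imidazole amide series

The source may report more compounds than this note shows. Statements on the series, on what has been measured and on what is new or still open speak of the compounds shown alone.

Compound 1 `COc1ccccc1-c1cnc(NC(=O)c2ccc(F)cc2)n1C` in a toxicity assay on THP-1 cells (Homo sapiens) for inhibition (a lower number here means that less compound is tolerated, a higher number that more compound is tolerated), gives only a limit, > 100000 nM. Compound 2 `Cn1c(-c2cccc(Cl)c2)cnc1NC(=O)c1ccc(F)cc1` likewise gives only a limit in this assay, > 50000 nM. Compound 3 `Cn1c(-c2ccccc2F)cnc1NC(=O)c1ccc(F)cc1` also reaches only a limit in this assay, > 100000 nM. Compound 3 therefore stands nowhere readable: the two other values are limits as well, two of them sitting at the limit of > 100000 nM in this assay, at which 2 of the 3 values shown sit, and one at the limit of > 50000 nM in this assay, at which 1 of the 3 values shown sits. The steps a step that the two limits leave unreadable from compound 1 to compound 3 and a step that the two limits leave unreadable from compound 2 to compound 3 bear directly on the position of compound 3, and the step that the two limits leave unreadable from compound 1 to compound 2 links the other two; none of the three can be read for size or direction.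

Compound 4 `Cn1c(-c2cccc(C#N)c2)cnc1NC(=O)c1ccc(F)cc1` differs from compound 3 in one place: 3-cyanophenyl in place of 2-fluorophenyl on an aromatic carbon.

With every measured step unreadable and all three values at a limit, the expected step is a number no higher from compound 3 to compound 4 (the limit leaves the size open), none beyond the scatter. Compound 4 is estimated in this assay at 100000 nM, in the range 50000 nM to 200000 nM, most likely reported as a limit again.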

Compound 4, half-maximal cytotoxic concentration: > 100000 nM
Compound 4 was reported as a limit; the forecaster's own chance of this, stated with the estimate: 80%; the middle value lies on the limit itself.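

In this assay compound 4 gives > 100000 nM, again a limit. Its steps from compound 1, compound 2 and compound 3 cannot be read for size or direction. Still open, as far as these compounds go, is where any of these four compounds reaches its half-maximal cytotoxic concentration, and whether the changed group matters at all.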